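Replacing the chlorophenyl sulfone of compound 1 with a diethylsulfonamide

This account rests on a few compounds, and the source may have more. Where it says the series, first, only, none or still open, it means among the compounds named here.

Going by the values given here, compound 1 `O=C(NCc1ccncc1)Nc1ccc(S(=O)(=O)c2ccc(Cl)cc2)cc1` is the weaker of the two compounds measured so far in an assay on isolated protein for activation of Nicotinamide phosphoribosyltransferase (Homo sapiens); on this read-out lower numbers stand for an effect already at smaller amounts and higher numbers for an effect only at larger amounts of compound: compound 1 gives 126 nM, while compound 2 `O=C(NCc1cn[nH]c1)Nc1ccc(S(=O)(=O)c2ccc(Cl)cc2)cc1` gives 23 nM. Among the compounds with values here, the only measured step, a 5.5-fold lower number from compound 1 to compound 2 (0.74 log units; beyond the scatter), concerns the group on the saturated chain carbon bound to the amide-type nitrogen, a different place from the one changed here.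

Compound 3 `CCN(CC)S(=O)(=O)c1ccc(NC(=O)NCc2ccncc2)cc1` differs from compound 1 in another part of the shared core: diethylamino in place of 4-chlorophenyl on a sulfonyl sulfur. Within the data shown here, no measured step touches the sulfonyl sulfur, so nothing in the data shows how this assay responds to such a change, and the expectation rests on the change itself rather than on a precedent. Compound 3 is therefore expected to give roughly 300 nM, with a range from 60 nM to 1500 nM. That estimate amounts to an expected step of a 2.4-fold higher number from compound 1 to compound 3 (0.38 log units; beyond the scatter), a modest loss, held with low confidence.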

Compound 3, half-maximal effective concentration: 384 nM
For compound 3 the middle estimate is 1.3-fold (0.11 log units) below the measured one, and the stated range covers the measured number.
By their numbers in this assay, from the lowest: compound 2; then compound 1; then compound 3.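

At the sulfonyl sulfur, this assay gives its first reading with a 3.0-fold higher number from compound 1 to compound 3 (0.48 log units; beyond the scatter), a modest step beyond the scatter, which shows that this position affects the read-out. The 4-chlorophenyl, with its six-membered aromatic ring, can give way to diethylamino, which has no ring, and compound 3 still keeps a measurable effect (384 nM). No available evidence accounts for the size of this step.

The compounds shown leave open whether 1H-pyrazol-4-yl in place of pyridin-4-yl, the change that lowered the number from compound 1 to compound 2, would do the same alongside diethylamino. They also leave open how a cyclic amine such as piperidin-1-yl or morpholin-4-yl, or a smaller dimethylamino, would read on the sulfonyl sulfur.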